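Swapping sulfur for selenium on a shared acylated core

A few compounds are considered here, and "the series" means these few. Any claim that something is new, unique, unknown or untested is made for them only; others in the source may bear on it.

Compound 3 `CS/C(=N\C(=O)c1cc(-c2ccccc2)nc2ccccc12)NC(=O)c1cc(-c2ccccc2)nc2ccccc12` carries a methylsulfanyl group on the carbon with a double bond to nitrogen. In a functional assay on MCF7 cells (Homo sapiens) for cytotoxicity, read by MTT assay, with a stated time of 72 h (a higher number here means a weaker inhibitor of growth, a lower number a stronger inhibitor of growth), compound 3 gives 87700 nM, the highest of the two numbers recorded. Its nearest neighbour is compound 1 `O=C(/N=C(/NC(=O)c1cc(-c2ccccc2)nc2ccccc12)[Se]Cc1ccccc1)c1cc(-c2ccccc2)nc2ccccc12`, which in this assay gives 45600 nM, and the step of a 1.9-fold higher number from compound 1 to compound 3 (0.28 log units; within the scatter) lies within the scatter. Compound 2 `O=C(/N=C(/NC(=O)c1cccs1)[Se]Cc1ccccc1)c1cccs1` gives in this assay only a limit, > 100000 nM, and so the limit of > 100000 nM in this assay, at which 1 of the 3 values shown sits, applies to it. Compound 4 `C[Se]/C(=N\C(=O)c1cc(-c2ccccc2)nc2ccccc12)NC(=O)c1cc(-c2ccccc2)nc2ccccc12` differs from compound 3 by a group of 2 heavy atoms (1 carbon, 1 selenium; no ring) in place of a group of 2 heavy atoms (1 carbon, 1 sulfur; no ring), on a carbon with a double bond to nitrogen. Among the measured compounds shown here, the single measured step that touches this position, a 1.9-fold higher number from compound 1 to compound 3 (0.28 log units; within the scatter), also exchanged selenium for sulfur, together with a larger change of the attached group, and it stayed within the scatter. No change beyond the scatter is therefore expected in this assay, and the estimated step is a 1.3-fold lower number from compound 3 to compound 4 (0.13 log units; within the scatter). Compound 4 is expected to give about 65000 nM in this assay, most likely between 30000 nM and 140000 nM, with a real chance that only a limit is reported.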

Compound 4, concentration for total growth inhibition: 7520 nM
The estimate for compound 4 lay 8.6-fold (0.94 log units) above the measured number; measured number outside the range, below it.
By their numbers in this assay, from the lowest: compound 4; then compounds 1 and 3 (each within the scatter of the next). At a limit, above all of these: compound 2.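

Among the compounds shown here, on the carbon with a double bond to nitrogen, exchanging only sulfur for selenium, with the methyl kept, gives a 12-fold lower number from compound 3 to compound 4 (1.07 log units; beyond the scatter) in this assay, so this single atom matters far more than the earlier compounds suggested. With selenium kept, hydrogen in place of phenyl on the saturated chain carbon bound to selenium gives a 6.1-fold lower number from compound 1 to compound 4 (0.78 log units; beyond the scatter) as a second, separate gain. Compound 1 and compound 3 lie within the scatter of each other, yet they differ by both changes, so their similar numbers hid two effects that pull in opposite directions.

As far as these compounds go, whether a longer chain such as ethyl on the selenium, or an amine in place of the whole selenium group, would keep this low number remains open. Nothing shown here accounts for the size of the selenium step.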